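The source may hold more compounds than are shown below. What is called first, only, known or untested is meant among the compounds shown, and "the series" means these compounds.

Compound 1 `O=C1NCCN1c1ccc(S(=O)(=O)Nc2ccc(I)cc2)cc1` gives, in a functional assay on MCF7 cells (Homo sapiens) for antiproliferative activity, read by sulforhodamine B assay, with a stated time of 48 h (on this read-out lower numbers stand for stronger inhibition and higher numbers for weaker inhibition), a value of 600 nM. Among the two results shown for this assay, compound 1 carries the only actual number; the other result is a limit of the assay rather than a number. Compound 2 `CC(C)(C)c1ccc(NS(=O)(=O)c2ccc(N3CCNC3=O)cc2)cc1` is that other case, reported in this assay only as > 1000 nM, a limit. For the measured compounds named here, the one measured step, tert-butyl in place of iodo on an aromatic carbon, gives an at least 1.6-fold higher number from compound 1 to compound 2 (0.22 log units; that floor lies within the scatter), and the floor of this step rests on (the limit of > 1000 nM in this assay, at which 1 of the 2 values shown sits).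

Compound 3 `COc1ccccc1NS(=O)(=O)c1ccc(N2CCNC2=O)cc1` shares the core of compound 1 and differs from it in one place: 2-methoxyphenyl in place of 4-iodophenyl on a sulfonamide nitrogen. Going by the values given here, no measured step matches this change, since the only step recorded alters a group on the aromatic carbon while keeping the 4-substituted phenyl pattern, whereas here the whole ring changes its substituent and its position. Among the compounds with values here, the single measured step points weakly toward a higher number when the iodo is lost, and a similar drift is expected here, so the step from compound 1 is estimated at a 2.5-fold higher number from compound 1 to compound 3 (0.40 log units; beyond the scatter). Compound 3 is therefore expected to give about 1500 nM in this assay, with a range from 500 nM to 5000 nM.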

Compound 3, half-maximal inhibitory concentration: 770 nM
The estimate for compound 3 lay 1.9-fold (0.29 log units) above the measured number; the range from low to high includes it.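

In this assay, exchanging the group on the sulfonamide nitrogen for one with a different substituent gives a 1.3-fold higher number from compound 1 to compound 3 (0.11 log units; within the scatter). Compound 1 and compound 3 therefore cannot be told apart in this assay: with the shared core unchanged, 2-methoxyphenyl serves as well as 4-iodophenyl, so iodine is not required for a measured value of this order. Compound 2 remains the one result reported only as a limit rather than a number: the limit of > 1000 nM in this assay, at which 1 of the 3 values shown sits.

Since the name of the ring changes in both the substituent and its number, the compounds shown cannot separate those two differences, and 4-methoxyphenyl or 2-iodophenyl on the same nitrogen would be needed to do so. Also open is how this position responds to an unsubstituted phenyl, or to a phenyl ring carrying an amine or a carboxylic acid, none of which appears among the compounds shown.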